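The compounds below may be only part of what the source reports. "The series", "measured", "known", "first", "only" and "open" are said of these compounds alone.

Measured so far:

Compound 1 `CCSC(=O)C1=C(C)NC(=O)NC1c1ccoc1` gives 1% in an assay on membranes from HeLa cells for displacement of a labelled ligand from adenosine receptor A3 (Homo sapiens), read by scintillation counting, with a stated time of 180 min, tested at 1 uM; a higher number here means more inhibition at the concentration tested (going by the name of the read-out), a lower number less inhibition.
Compound 2 `CC1=C(C(=O)SC(C)C)C(c2ccoc2)NC(=O)N1` gives 3% in this assay.
Compound 3 `CCC(CC)OC(=O)C1=C(C)NC(=O)NC1c1ccsc1` gives 6% in this assay.

All three numbers sit within the scatter of one another, so none can be set apart. Compound 4 `CCC(C)OC(=O)C1=C(C)NC(=O)NC1c1ccsc1` has not yet been measured in this assay. It differs from compound 3 by hydrogen in place of methyl on a saturated chain carbon, two bonds along the chain from an oxygen next to a carbonyl group. The same kind of change, though not the same, was made between two measured compounds: compound 1 differs from compound 2 by hydrogen in place of methyl on a saturated chain carbon bound to a saturated chain carbon and a sulfur, and that step gave a number 2 percentage points lower from compound 2 to compound 1 (within the scatter). The two places are not alike: in compound 2 the carbon is bound to a saturated chain carbon and a sulfur, in compound 3 it is two bonds along the chain from an oxygen next to a carbonyl group. The difference between the two cores is not broken down here. Because a number 2 percentage points lower from compound 2 to compound 1 (within the scatter) was within the scatter, compound 4 is expected to move from compound 3 by a number 1 percentage points lower from compound 3 to compound 4 (within the scatter), that is, to stay near its parent. Compound 4 is estimated at 5%, between 0% and 14%.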

Compound 4, a percentage reported as inhibition, at one concentration (the size of the read-out at that concentration, not a potency): 7%
Estimate against measurement, compound 4: 2 percentage points below; measured number inside the range.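

Cutting pentan-3-yl back to sec-butyl gives a number 1 percentage points higher from compound 3 to compound 4 (within the scatter) in this assay. Set beside the earlier case of the same kind of change, on a different core, the two steps do not differ: the same change on two cores in this assay, a number 2 percentage points lower (within the scatter) from compound 2 to compound 1 and a number 1 percentage points higher (within the scatter) from compound 3 to compound 4, 3 percentage points apart, within the scatter of two such steps. Among these compounds, this shows that on both cores the change left the number within the scatter, but it does not show that the change would carry over to a compound with a clearly larger number, and no compound here stands apart from the others.

The compounds shown leave open what an amine or a carboxylic acid on this chain would do, or a chain longer than pentan-3-yl. They also leave open whether any change at this place could move the number beyond the scatter.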